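The source may hold more compounds than are shown below. What is called first, only, known or untested is meant among the compounds shown, and "the series" means these compounds.

Three compounds share a common scaffold and were tested in a functional assay on LS174T cells (Homo sapiens) for inhibition, with a stated time of 4 days, tested at 10 uM; on this read-out higher numbers stand for a stronger effect at the one concentration tested and lower numbers for a weaker effect. Compound 1 `Nc1ccnc2cc(C#Cc3c(F)cccc3F)ccc12` gives 97.7%. Compound 3 `Nc1ncc(C#Cc2c(F)cccc2F)c2ccccc12` gives 93.1%. Compound 2 `Fc1cccc(F)c1C#Cc1cncc2ccccc12` gives 87.9%. From compound 3 to compound 2 the change is hydrogen in place of amino on an aromatic carbon, and the step is a number 5.2 percentage points lower from compound 3 to compound 2 (within the scatter). The difference between the cores of compound 1 and compound 3 is not broken down here. Compound 4 `Fc1cccc(F)c1C#Cc1ccc2cccnc2c1` has not yet been measured; it differs from compound 1 by hydrogen in place of amino on an aromatic carbon, the same kind of change as before, though the place is now opposite the ring nitrogen instead of next to the ring nitrogen and para to a large group. Because the earlier step was a number 5.2 percentage points lower from compound 3 to compound 2 (within the scatter), the expected step is a number 5.7 percentage points lower from compound 1 to compound 4 (within the scatter). Compound 4 is therefore estimated at 92%, between 80% and 99%.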

Compound 4, a percentage reported as inhibition, at one concentration (the size of the read-out at that concentration, not a potency): 99.4%
Compound 4: the middle estimate sits 7.4 percentage points below what was measured; measured number outside the range, above it.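

In this assay, putting hydrogen in place of amino on the core of compound 1 gives a number 1.7 percentage points higher from compound 1 to compound 4 (within the scatter). Set beside the same change on the other core, the two steps do not differ: the same change on two cores in this assay, a number 5.2 percentage points lower (within the scatter) from compound 3 to compound 2 and a number 1.7 percentage points higher (within the scatter) from compound 1 to compound 4, 6.9 percentage points apart, within the scatter of two such steps
So in these two cores, removing the amino group leaves the read-out within the usual scatter, but two pairs tested at one concentration give no potency and say nothing about a third core.

From the compounds shown here alone, it remains open whether a real difference between these compounds would appear in a full concentration series. The compounds shown also leave open what a larger group in the same place, such as a methoxy group or a carboxylic acid, would do.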